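The compounds below may be only part of what the source reports. "The series", "measured", "known", "first", "only" and "open" are said of these compounds alone.

Compound 1 `O=c1cc(CSC(=S)N2CCCCC2)oc2cc(Cl)ccc12` in a functional assay on LM7 cells (Homo sapiens) for antiproliferative activity, read by MTT assay, with a stated time of 72 h (on this read-out higher numbers stand for weaker inhibition and lower numbers for stronger inhibition), gives 13800 nM, the highest of the two numbers recorded; compound 2 `COc1ccc2oc(CSC(=S)N3CCCCC3)cc(=O)c2c1` in this assay gives 5000 nM, the nearest value and beyond the scatter from compound 1. The unmeasured compound 3 `CCN(CC)C(=S)SCc1cc(=O)c2ccc(Cl)cc2o1` carries diethylamino in place of piperidin-1-yl on a thiocarbonyl carbon. Nothing in the measured pair speaks to this exchange, and the two groups are close in size and identical in donor and acceptor count, so no step beyond the scatter is expected in this assay. The expected step of a 1.2-fold lower number from compound 1 to compound 3 (0.06 log units; within the scatter) is accordingly small. Compound 3 is estimated at 12000 nM in this assay, within 5000 nM to 30000 nM.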

Compound 3, half-maximal inhibitory concentration: 8800 nM
Estimate against measurement, compound 3: 1.4-fold (0.13 log units) above; low and high end bracket the measured number.
By their numbers in this assay, from the lowest: compounds 2, 3 and 1 (each within the scatter of the next, the first and the last beyond it).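

For the compounds shown here, the step of a 1.6-fold lower number from compound 1 to compound 3 (0.20 log units; within the scatter) in this assay is the first reading at this position: with the chlorinated core of compound 1 held constant, the piperidin-1-yl ring can be opened to diethylamino on a thiocarbonyl carbon without a change beyond the scatter. An intact ring at this position is therefore not required for activity in this pair. Nothing available explains this tolerance.

Open, from the compounds shown here alone, are morpholine or piperazine at this position and longer chains such as dibutylamino. Also open, going by these compounds, is whether the exchange behaves the same way on the core of compound 2.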